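A few compounds are considered here, and "the series" means these few. Any claim that something is new, unique, unknown or untested is made for them only; others in the source may bear on it.

Measured so far:
- compound 1 `CCc1ccc(C(=O)/C=C/C(=O)O)cc1` gives 27800 nM in a functional assay on HeLa cells (Homo sapiens) for inhibition, read by MTT assay, with a stated time of 72 h; on this read-out lower numbers stand for stronger inhibition and higher numbers for weaker inhibition
- compound 2 `O=C(O)/C=C/C(=O)c1cc(C2CCCCC2)ccc1C1CCCCC1` gives 1260 nM in this assay

Compound 1 stands at the highest of the two numbers; compound 2 sits at a lower number, and the gap between them lies beyond the usual scatter. Going by the values given here, no step between measured compounds that differ in one place is available, so the pair shows only what its two values show.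

Compound 3 `O=C(O)/C=C/C(=O)c1ccccc1` is not yet measured. It differs from compound 1 in one place: hydrogen in place of ethyl on an aromatic carbon. The change removes the only substituent from the core of compound 1. With nothing else to lean on, a modest step towards weaker inhibition is expected, though it may fall within the scatter. Compound 3 is estimated at 50000 nM (range 18000 nM to 150000 nM), an expected step of a 1.8-fold higher number from compound 1 to compound 3 (0.25 log units; within the scatter).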

Compound 3, half-maximal inhibitory concentration: 30600 nM
Compound 3: the middle estimate sits 1.6-fold (0.21 log units) above what was measured; the range from low to high includes it.
By their numbers in this assay, from the lowest: compound 2; then compounds 1 and 3 (each within the scatter of the next).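

Hydrogen in place of ethyl on an aromatic carbon, para to a group of 7 heavy atoms, gives a 1.1-fold higher number from compound 1 to compound 3 (0.04 log units; within the scatter) in this assay. This first one-place step in the series leaves no readable difference between ethyl and hydrogen at this position, so on this read-out the ethyl group of compound 1 cannot be told apart from the unsubstituted ring of compound 3. No measurement bears on this result.

On these data alone, whether a longer chain or an amine at this position would move the number beyond the scatter remains open, since ethyl is the only substituent tested here. Compound 2 gives 1260 nM but differs from compound 3 in more than one place, so that value cannot yet be tied to any single change.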